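The compounds below may be only part of what the source reports. "The series", "measured", "known", "first", "only" and "open" are said of these compounds alone.

Compound 1 `CC1=CC[C@@H]([C@@](C)(O)CCCC(C)(C)NC(=S)N/N=C\c2ccccc2)CC1` is the starting point. In a functional assay on NCI-H460 cells (Homo sapiens) for cytotoxicity, read by sulforhodamine B assay (a lower number here means a stronger inhibitor of growth, a higher number a weaker inhibitor of growth), compound 1 gives 38400 nM. Two close relatives have been measured alongside it. Compound 2 `COc1ccc(/C=N\NC(=S)NC(C)(C)CCC[C@](C)(O)[C@@H]2CC=C(C)CC2)cc1` carries a methoxy group on the aromatic ring and gives 5100 nM; compound 3 `CC1=CC[C@@H]([C@@](C)(O)CCCC(C)(C)NC(=S)N/N=C\c2ccccc2[N+](=O)[O-])CC1` carries a nitro group on that ring and gives 20600 nM. Compound 1 thus has the highest number of the three: the step of a 7.5-fold lower number from compound 1 to compound 2 (0.88 log units; beyond the scatter) lies beyond the usual scatter of repeated measurements, while the step of a 1.9-fold lower number from compound 1 to compound 3 (0.27 log units; within the scatter) does not, so compound 1 and compound 3 cannot be told apart with confidence.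

Compound 4 `CC1=CC[C@@H]([C@@](C)(O)CCCC(C)(C)NC(=S)N/N=C\c2ccc([N+](=O)[O-])cc2)CC1` comes next. Relative to compound 1 it differs in one place: nitro in place of hydrogen on an aromatic carbon. Within the data shown here, two measured steps bear on this change. The step of a 1.9-fold lower number from compound 1 to compound 3 (0.27 log units; within the scatter) put the same nitro group onto the same ring and gave only a small change. The step of a 7.5-fold lower number from compound 1 to compound 2 (0.88 log units; beyond the scatter) put a methoxy group onto that ring and gave a modest lowering. A modest lowering is therefore expected for compound 4, roughly a 2.7-fold lower number from compound 1 to compound 4 (0.44 log units; beyond the scatter). Compound 4 is estimated at 14000 nM, with a likely range from 5000 nM to 35000 nM.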

Compound 4, concentration for 50% growth inhibition: 10100 nM
Compound 4: the middle estimate sits 1.4-fold (0.14 log units) above what was measured; the measured number falls inside the stated range.
By their numbers in this assay, from the lowest: compounds 2 and 4 (each within the scatter of the next); then compounds 3 and 1 (each within the scatter of the next).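

Moving the nitro group to the position para to a large group gives a step that the 2-nitrophenyl ring of compound 3 did not: in this assay, the change from plain phenyl gives a 3.8-fold lower number from compound 1 to compound 4 (0.58 log units; beyond the scatter), which lies beyond the usual scatter. Where the same group sits on this ring therefore counts, since the switch from 2-nitrophenyl to 4-nitrophenyl gives a 2.0-fold lower number from compound 3 to compound 4 (0.31 log units; beyond the scatter), although this step is only modest. At the same ring position, swapping methoxy for nitro gives a 2.0-fold higher number from compound 2 to compound 4 (0.30 log units; within the scatter), which lies within the scatter, so these two very different groups cannot be told apart in this assay, and a nitro group is as compatible with growth inhibition here as a methoxy group.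

No measurement shown here accounts for these differences. As far as these compounds go, it remains open whether an amine or a carboxylic acid at this same ring position would give a number close to those of compound 2 and compound 4, or whether the ring tolerates almost any group there.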